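Iodo to thiophenyl on a methoxy-bearing nucleoside core

The source may hold more compounds than are shown below. What is called first, only, known or untested is meant among the compounds shown, and "the series" means these compounds.

Measured compounds:
compound 1 `Nc1nc(N)c2c(-c3cc4ccccc4o3)cn([C@@H]3O[C@H](CO)[C@@H](O)[C@H]3O)c2n1` — > 15000 nM
compound 2 `COc1ncnc2c1c(I)cn2[C@@H]1O[C@H](CO)[C@@H](O)[C@H]1O` — 2300 nM
compound 3 `Nc1nc(N)c2c(-c3ccoc3)cn([C@@H]3O[C@H](CO)[C@@H](O)[C@H]3O)c2n1` — > 20000 nM

Among the compounds with values here, in a functional assay on HL-60 cells (Homo sapiens) for antiproliferative activity, read by XTT assay, with a stated time of 72 h (a higher number here means a weaker inhibitor, a lower number a stronger inhibitor), compound 2 gives 2300 nM, the only value in this set reported as a number. For compound 1 the result is a limit of the assay, > 15000 nM, as stated in the limit of > 15000 nM in this assay, at which 1 of the 3 values shown sits. For compound 3 the result is likewise a limit, > 20000 nM, as stated in the limit of > 20000 nM in this assay, at which 1 of the 3 values shown sits. Within the data shown here, the one step between measured compounds, a step that the two limits leave unreadable from compound 1 to compound 3, therefore cannot be read in size or direction, because both ends are limits.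

Compound 4 `COc1ncnc2c1c(-c1ccsc1)cn2[C@@H]1O[C@H](CO)[C@@H](O)[C@H]1O` differs from compound 2 by thiophen-3-yl in place of iodo on an aromatic carbon. Among the measured compounds shown here, no measured step shares this change on the core of compound 2; compounds 1 and 3 carry aryl groups at the same place on a different core, and both sit at limits. That offers no readable guide to the direction of the change, but it shows that bulky aromatic groups at this position did not yield measurable potency in this assay for those two compounds. The step from compound 2 to compound 4 is therefore expected as a modest loss, a 2.6-fold higher number from compound 2 to compound 4 (0.42 log units; beyond the scatter), with wide uncertainty. Compound 4 is estimated at 6000 nM, in the range 1500 nM to 25000 nM.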

Compound 4, half-maximal inhibitory concentration: 130 nM
Compound 4: middle estimate off by 46-fold (1.66 log units), on the high side; the whole stated range lies above it.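

In this assay, within the data shown here, the change from iodo to thiophen-3-yl gives an 18-fold lower number from compound 2 to compound 4 (1.25 log units; beyond the scatter) and is the first step at this position that can be read in both size and direction. It shows that on the core of compound 2, this aromatic carbon, two ring bonds from the ring nitrogen, can carry a five-membered aromatic ring with a large gain in potency rather than a loss. The values shown give no reason for this gain.

Compounds 1 and 3 carry their aryl groups on a different core and differ from compound 4 in more than one place, leaving open whether furan-3-yl or 1-benzofuran-2-yl would also give a gain on the core of compound 2, and whether the diamino-substituted core or the aryl group accounts for their lack of a measured number. Going by these compounds, it also remains open whether the gain needs an aromatic ring at all, or whether a small amine, a nitrile or a short alkyl chain at this place would match thiophen-3-yl.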